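Chloro to methoxy on a core inert to HUVEC cells

This account rests on a few compounds, and the source may have more. Where it says the series, first, only, none or still open, it means among the compounds named here.

Three compounds with one shared core were tested in a toxicity assay on HUVEC cells (Homo sapiens) for cytotoxicity, read by MTT assay, with a stated time of 48 h; on this read-out higher numbers stand for weaker inhibition of growth and lower numbers for stronger inhibition of growth. Compound 1 `CCOc1ccc2nc(Cl)c(/C=C3\SC(=S)NC3=O)cc2c1` reached only the assay limit of > 100 ug/mL. Compound 2 `O=C1NC(=S)S/C1=C\c1cc2cc(Cl)ccc2nc1Cl` likewise stopped at the limit of > 100 ug/mL. Compound 3 `COc1ccc2cc(/C=C3\SC(=S)NC3=O)c(Cl)nc2c1` also gave only the limit of > 100 ug/mL. Among the measured compounds shown here, the single measured step cannot be sized because a step that the two limits leave unreadable from compound 1 to compound 2 has a limit at both ends, and the limit of > 100 ug/mL in this assay, at which 3 of the 3 values shown sit, holds every value shown. Compound 4 `COc1ccc2nc(Cl)c(/C=C3\SC(=S)NC3=O)cc2c1` differs from compound 2 by methoxy in place of chloro on an aromatic carbon. Compound 1, carrying ethoxy at that place, also gave only the limit of > 100 ug/mL. Compound 4 is therefore expected to remain at 150 ug/mL, in a range from 60 ug/mL to 400 ug/mL. The expected step that the limit leaves unreadable from compound 2 to compound 4 is estimated to lie within the scatter.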

Compound 4, concentration for 50% growth inhibition: > 100 ug/mL
Compound 4: a limit, no number (the forecaster's own chance of this, stated with the estimate: 85%); the middle value lies beyond the limit too.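

No step among compound 1, compound 2 and compound 4 can be read, since each gives only a limit: the limit of > 100 ug/mL in this assay, at which 4 of the 4 values shown sit.

The compounds shown leave open how far each lies past this limit, and whether chloro, methoxy or ethoxy at that place makes any difference in this assay.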